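An Acetyl Group Where Propyl Raised and Formyl Did Not

This account rests on a few compounds, and the source may have more. Where it says the series, first, only, none or still open, it means among the compounds named here.

Compound 1 `CC(=O)c1ccc(OCCCCC#N)cc1O` gives 0% in an assay on isolated protein for inhibition of leukotriene B4 receptor 1 (Homo sapiens), tested at 10 uM; on this read-out lower numbers stand for less inhibition and higher numbers for more inhibition at the one concentration tested (going by the name of the read-out).
Compound 2 `CCCc1cc(C(C)=O)c(O)cc1OCCCCC#N` gives 84% in this assay.
Compound 3 `CC(=O)c1cc(C=O)c(OCCCCC#N)cc1O` gives 6% in this assay.

Compound 1 stands lowest of the three, with compound 3 nearest and compound 2 furthest. Compound 4 `CC(=O)c1cc(C(C)=O)c(OCCCCC#N)cc1O` differs from compound 1 by acetyl in place of hydrogen on an aromatic carbon. Two measured steps from compound 1 bear on this: a number 84 percentage points higher from compound 1 to compound 2 (beyond the scatter) and a number 6 percentage points higher from compound 1 to compound 3 (within the scatter). Acetyl, with its one double bond outside the ring, resembles formyl far more than the plain propyl chain, and a number 78 percentage points lower from compound 2 to compound 3 (beyond the scatter) shows how far formyl falls short of propyl here. A small step is therefore expected, a number 12 percentage points higher from compound 1 to compound 4 (beyond the scatter), likely within the scatter. Compound 4 is estimated at 12%, between 0% and 40%.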

Compound 4, a percentage reported as inhibition, at one concentration (the size of the read-out at that concentration, not a potency): 8%
Estimate against measurement, compound 4: 4 percentage points above; measured number inside the range.
By their numbers in this assay, from the lowest: compounds 1, 3 and 4 (each within the scatter of the next); then compound 2.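

In this assay acetyl at this position reads like formyl and not like propyl, with a number 8 percentage points higher from compound 1 to compound 4 (within the scatter) and a number 2 percentage points higher from compound 3 to compound 4 (within the scatter) while a number 76 percentage points lower from compound 2 to compound 4 (beyond the scatter). Both carbonyl-bearing groups now stay within the scatter of plain hydrogen, so of the three groups tried here, propyl alone stands apart. Nothing shown gives a reason for this. From the compounds shown here alone, whether an ethyl group, a longer chain such as butyl, or an amine at this position would match propyl or fall with acetyl stays open.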